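Methyl for bromo in a weakly cytotoxic series

The source may hold more compounds than are shown below. What is called first, only, known or untested is meant among the compounds shown, and "the series" means these compounds.

Compound 1 `Cc1ccc(S(=O)(=O)N2C(=O)NCC2c2ccc(Br)cc2)cc1`: 67000 nM
Compound 2 `O=C1NCC(c2ccc(Br)cc2)N1S(=O)(=O)c1ccc(Cl)cc1`: 84000 nM

Going by the values given here, in a functional assay on A549 cells (Homo sapiens) for cytotoxicity (a higher number here means a weaker inhibitor, a lower number a stronger inhibitor), compound 2 gives 84000 nM, which lies within the scatter of compound 1, the only other compound measured. Compound 3 `Cc1ccc(C2CNC(=O)N2S(=O)(=O)c2ccc(Cl)cc2)cc1` differs from compound 2 in one place: methyl in place of bromo on an aromatic carbon. In words, this is methyl in place of bromo on an aromatic carbon, para to a large group.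

Among the compounds with values here, one measured step bears on this change. It also exchanges a methyl and a halogen, chloro in place of methyl on an aromatic carbon, but at a different place in the molecule: a 1.3-fold higher number from compound 1 to compound 2 (0.10 log units; within the scatter). Within the data shown here, that step stays within the scatter, though no measured step touches the bromo position itself. No shift beyond the scatter is therefore expected, and the estimated change is a 1.1-fold lower number from compound 2 to compound 3 (0.05 log units; within the scatter). Compound 3 is expected to give about 75000 nM, within an estimated range of 38000 nM to 150000 nM.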

Compound 3, half-maximal inhibitory concentration: 266000 nM
Estimate against measurement, compound 3: 3.5-fold (0.55 log units) below; measured number above the stated range.
By their numbers in this assay, from the lowest: compounds 1 and 2 (each within the scatter of the next); then compound 3.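

In this assay, going by these compounds alone, the exchange of 4-bromophenyl for 4-methylphenyl produces a step beyond the scatter (a 3.2-fold higher number from compound 2 to compound 3 (0.50 log units; beyond the scatter)), the first such step, with the higher number marking a weaker inhibitor. The earlier exchange of methyl and chloro at the other place in the molecule stayed within the scatter (a 1.3-fold higher number from compound 1 to compound 2 (0.10 log units; within the scatter)), so that result did not carry over to this position, where replacing one heavy atom is enough to move the number. Nothing available accounts for this difference between the two positions.

Going by these compounds, it remains open whether chloro, fluoro or a methoxy group at this position would stay with bromo or move with methyl. Also open, on these data alone, is whether the step would keep its size with methyl rather than chloro at the other place.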